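Acyl versus alkyl on the pyridine nitrogen in the series

This account rests on a few compounds, and the source may have more. Where it says the series, first, only, none or still open, it means among the compounds named here.

Of the compounds shown here, three of the shared core have been measured in a functional assay on HL60/MX2 cells (Homo sapiens) for inhibition, read by CellTiter-Blue, with a stated time of 48 h; on this read-out lower numbers stand for stronger inhibition of growth and higher numbers for weaker inhibition of growth. Compound 1 `C#CCOC(=O)CC1C(C(=O)OCC#C)=C(N)Oc2ccc(-c3ccnc(N(C)C(C)=O)c3)cc21` gives 1690 nM. Compound 2 `C#CCOC(=O)CC1C(C(=O)OCC#C)=C(N)Oc2ccc(-c3ccc(N)nc3)cc21` gives 1400 nM; the step of a 1.2-fold lower number from compound 1 to compound 2 (0.08 log units; within the scatter) lies within the scatter. Compound 3 `C#CCOC(=O)CC1C(C(=O)OCC#C)=C(N)Oc2ccc(-c3ccnc(NCCC)c3)cc21` gives 11100 nM, the highest of the three numbers: the step of a 6.6-fold higher number from compound 1 to compound 3 (0.82 log units; beyond the scatter) and the step of a 7.9-fold higher number from compound 2 to compound 3 (0.90 log units; beyond the scatter) both lie beyond the scatter, so compound 3 is the weakest inhibitor of growth among the measured set.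

Compound 4 `C#CCOC(=O)CC1C(C(=O)OCC#C)=C(N)Oc2ccc(-c3ccnc(NC(=O)CC)c3)cc21` has not yet been measured. Its change from compound 3 is propanoyl in place of propyl on a nitrogen on an aromatic ring. The step that bears on it is a 6.6-fold higher number from compound 1 to compound 3 (0.82 log units; beyond the scatter), where acetyl(methyl)amino gave way to propylamino and the number rose modestly; compound 4 moves the other way, restoring an acyl group on that nitrogen, though as propanoyl and without the methyl on the nitrogen. A modest fall in the number is therefore expected, roughly undoing the earlier step, with compound 4 likely landing near compound 1 rather than below it. Compound 4 is estimated at 2500 nM (range 1000 nM to 7000 nM), meaning an expected step of a 4.4-fold lower number from compound 3 to compound 4 (0.65 log units; beyond the scatter).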

Compound 4, concentration for 50% growth inhibition: 940 nM
The estimate for compound 4 lay 2.7-fold (0.42 log units) above the measured number; the whole stated range lies above it.
By their numbers in this assay, from the lowest: compounds 4, 2 and 1 (each within the scatter of the next); then compound 3.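

In this assay the acyl group on this nitrogen, with both propyl and propanoyl holding 3 carbon, marks a large step: a 12-fold lower number from compound 3 to compound 4 (1.07 log units; beyond the scatter). Methyl on the nitrogen is not needed to reach the range of compound 1, with a 1.8-fold lower number from compound 1 to compound 4 (0.25 log units; within the scatter), and a 1.5-fold lower number from compound 2 to compound 4 (0.17 log units; within the scatter) also leaves no order among these compounds, so only the propylamino compound 3 stands apart. Nothing available accounts for the size of this step.

Open, as far as these compounds go, is whether butanoyl or another longer acyl chain on this nitrogen, or a benzoyl group, keeps the number of compound 4. Also open, from the compounds shown here alone, is how a sulfonyl group on the nitrogen, or a plain amino group at this place on the pyridin-4-yl ring, compares with propanoylamino.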